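This account rests on a few compounds, and the source may have more. Where it says the series, first, only, none or still open, it means among the compounds named here.

Measured so far in an assay on CV-1 cells with Bile acid receptor (Homo sapiens) as the target, read by a luciferase reporter; on this read-out higher numbers stand for an effect only at larger amounts of compound and lower numbers for an effect already at smaller amounts:
compound 1 `CC(C)c1onc(-c2c(Cl)cccc2Cl)c1COc1ccc2sc(-c3cccc(C(=O)O)c3)cc2c1` gives 32 nM;
compound 2 `CC(C)c1onc(-c2c(Cl)cccc2Cl)c1COc1ccc2sc(-c3ccc(C(=O)O)cc3)cc2c1` gives 160 nM;
compound 3 `CC(C)c1onc(-c2c(Cl)cccc2Cl)c1COc1ccc2cc(-c3cccc(C(=O)O)c3)ccc2c1` gives 130 nM.

From compound 1 to compound 2 the change is 4-carboxyphenyl in place of 3-carboxyphenyl on an aromatic carbon. It gave a 5.0-fold higher number from compound 1 to compound 2 (0.70 log units; beyond the scatter). Compound 4 `CC(C)c1onc(-c2c(Cl)cccc2Cl)c1COc1ccc2cc(-c3ccc(C(=O)O)cc3)ccc2c1` is not yet measured; it differs from compound 3 by 4-carboxyphenyl in place of 3-carboxyphenyl on an aromatic carbon. The difference between the core of compound 1 and the core of compound 3 is not broken down here. The two changes are the same kind of change, not the same: in compound 1 the place is on an aromatic carbon of a five-membered aromatic ring with one sulfur, next to the ring sulfur; in compound 3 it is on an aromatic carbon of a six-membered aromatic ring of carbon only, meta to a fused ring and para to a fused ring. In this assay compound 4 is expected to move by a 3.8-fold higher number from compound 3 to compound 4 (0.59 log units; beyond the scatter). This expectation rests on the earlier step, a 5.0-fold higher number from compound 1 to compound 2 (0.70 log units; beyond the scatter), with the different place a reason for caution. Compound 4 is estimated at 500 nM, between 200 nM and 1500 nM.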

Compound 4, half-maximal effective concentration: 980 nM
Compound 4: the middle estimate sits 2.0-fold (0.29 log units) below what was measured, and the stated range covers the measured number.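

In this assay, 4-carboxyphenyl in place of 3-carboxyphenyl on the second core gave a 7.5-fold higher number from compound 3 to compound 4 (0.88 log units; beyond the scatter). The change carried over from the core of compound 1 to the core of compound 3 in the same direction and, within the scatter, by the same size: the same change on two cores in this assay, a 5.0-fold higher number (0.70 log units; beyond the scatter) from compound 1 to compound 2 and a 7.5-fold higher number (0.88 log units; beyond the scatter) from compound 3 to compound 4, 1.5-fold (0.18 log units) apart, within the scatter of two such steps This rests on two pairs only and does not show that the step would hold on any other core, nor why 3-carboxyphenyl gives the lower number in both pairs.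

Still open, going by these compounds, is how an amide or a nitrile in place of the carboxylic acid would read on either core. Also open, on these data alone, is whether a longer chain carrying the carboxylic acid would keep the same step.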